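Compound 3 to compound 4: hydroxymethyl to ethyl

This account rests on a few compounds, and the source may have more. Where it says the series, first, only, none or still open, it means among the compounds named here.

Measured compounds, all in a functional assay on the whole organism with Mus musculus as the target; a higher number here means that more compound is needed for the effect, a lower number that less compound is needed:
- compound 1 `CCCN(c1ccncc1)n1cccc1`: > 20 mg/kg
- compound 2 `CCCCN(c1ccncc1)n1cccc1`: > 20 mg/kg
- compound 3 `CN(c1ccncc1)n1cccc1CO`: > 20 mg/kg

Among the compounds with values here, each of these entries is a limit and not a number, so the series so far offers only (the limit of > 20 mg/kg in this assay, at which 3 of the 3 values shown sit). Compound 3 stands at the limit > 20 mg/kg.

The unmeasured compound 4 `CCc1cccn1N(C)c1ccncc1` differs from compound 3 by methyl in place of hydroxy on a saturated chain carbon bound to an aromatic carbon, which is methyl in place of hydroxy on a saturated chain carbon bound to an aromatic carbon. Within the data shown here, the only measured step is a step that the two limits leave unreadable from compound 1 to compound 2. That step is a different change, methyl in place of hydrogen, and it gives no size to carry over. Among the measured compounds shown here, no step of known size therefore bears on this change, and no clear move is expected in this assay, though a move to a lower dose remains open. The expected step is a step that the limit leaves unreadable from compound 3 to compound 4. For compound 4 the estimated value is 25 mg/kg, with an expected range of 8 mg/kg to 60 mg/kg.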

Compound 4, dose for half-maximal effect: > 20 mg/kg
Compound 4: only a limit was reported; the forecaster's own chance of this, stated with the estimate: 70%; the middle value is on the limit's open side.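

In this assay compound 3 and compound 4 are both limits and not numbers, so no step between them can be read, and the series rests on one limit: the limit of > 20 mg/kg in this assay, at which 4 of the 4 values shown sit.

The compounds shown leave open whether any change on the shared core gives a readable dose in this assay.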